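The compounds below may be only part of what the source reports. "The series", "measured", "known", "first", "only" and "open" are said of these compounds alone.

Measured compounds:
compound 1 `Nc1ccccc1NC(=O)c1ccc(CSC(=S)N2CCN(c3ccccc3)CC2)cc1` gives 88.6%
compound 2 `COc1ccc(N2CCN(C(=S)SCc3ccc(C(=O)Nc4ccccc4N)cc3)CC2)cc1` gives 35.9%
compound 3 `CCN(Cc1ccncc1)C(=S)SCc1ccc(C(=O)Nc2ccccc2N)cc1` gives 86.2%

All three numbers come from a functional assay on A-375 cells (Homo sapiens) for antiproliferative activity, read by CCK-8 assay, with a stated time of 72 h, tested at 8 uM; on this read-out lower numbers stand for a weaker effect and higher numbers for a stronger effect at the one concentration tested. Compound 3 stands second highest of the three: its value and that of compound 1 lie within the scatter of each other, so no order between them is claimed, while compound 2 lies well below both. Going by the values given here, the one single-point step in the set, a number 52.7 percentage points lower from compound 1 to compound 2 (beyond the scatter), shows that a small change far out on the thiocarbonyl-bound amine can cost a large part of the effect.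

Compound 4 `CN1CCN(C(=S)SCc2ccc(C(=O)Nc3ccccc3N)cc2)CC1` is not yet measured. It differs from compound 3 by 4-methylpiperazin-1-yl in place of ethyl((pyridin-4-yl)methyl)amino on a thiocarbonyl carbon. Among the compounds with values here, no measured step covers this exchange of amine on the thiocarbonyl carbon; the step from compound 1 to compound 2 bears on it only indirectly, by showing that this region of the molecule tolerates some changes poorly. Compound 4 carries a smaller, non-aromatic ring in place of the group of compound 3, a change unlike any measured one, so the direction is open. Because compound 3 gives 86.2% and compound 1 gives 88.6% with a different amine at the same place, a moderate loss is expected, with wide uncertainty: compound 4 is estimated at 65%, range 30% to 92%. The expected step is a number 21.2 percentage points lower from compound 3 to compound 4 (beyond the scatter).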

Compound 4, a percentage reported as inhibition, at one concentration (the size of the read-out at that concentration, not a potency): 91.6%
Beside the measured number, compound 4's estimate is 26.6 percentage points below it, within the range that was stated.
By their numbers in this assay, from the lowest: compound 2; then compounds 3, 1 and 4 (each within the scatter of the next).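

In this assay, 4-methylpiperazin-1-yl on the thiocarbonyl carbon matches ethyl((pyridin-4-yl)methyl)amino, a number 5.4 percentage points higher from compound 3 to compound 4 (within the scatter), so among these compounds an aromatic ring in the amine on the thiocarbonyl carbon is not required for the effect at this concentration. On the amine nitrogen in the ring, methyl and phenyl cannot be told apart, a number 3 percentage points higher from compound 1 to compound 4 (within the scatter), whereas exchanging 4-methoxyphenyl for methyl gives a number 55.7 percentage points higher from compound 2 to compound 4 (beyond the scatter), which places the low value of compound 2 with the 4-methoxyphenyl group rather than with every aryl group at that nitrogen. No measured property of these compounds bears on these steps.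

Compounds 1, 3 and 4 sit within the scatter of one another at a single concentration, so the data leave open whether their potencies differ, and a full concentration series would be needed to settle this. Also open, going by these compounds, are whether a morpholine in place of the piperazine or a longer alkyl chain on the ring nitrogen keeps this level, and whether a fluorine or hydroxyl in place of the methoxy on the phenyl ring gives the same drop as compound 2.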